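The compounds below may be only part of what the source reports. "The series", "measured", "known", "first", "only" and "open" are said of these compounds alone.

Compound 1 `Cc1ccc(NC(=O)c2c(NO)cc(-c3ccccc3)oc2=O)cc1` carries a plain phenyl on the shared core. In an ADME assay on Huh-7 cells (Homo sapiens) for cytotoxicity, read by a luciferase reporter and WST assay, with a stated time of 3 days (a lower number here means that less compound is tolerated, a higher number that more compound is tolerated), compound 1 gives > 20000 nM, which is a limit of the assay rather than a number. Compound 2 `Cc1ccc(NC(=O)c2c(NO)cc(-c3ccc(F)cc3)oc2=O)cc1` differs by fluoro in place of hydrogen on an aromatic carbon, and in this assay compound 2 gives > 20000 nM, again a limit. Compound 3 `Cc1ccc(NC(=O)c2c(NO)cc(-c3ccc(C)cc3)oc2=O)cc1` differs from compound 1 by methyl in place of hydrogen on an aromatic carbon, and in this assay compound 3 gives > 20000 nM, also a limit. Compound 3 therefore stands at the same limit as the other two. The steps a step that the two limits leave unreadable from compound 1 to compound 2, a step that the two limits leave unreadable from compound 1 to compound 3 and a step that the two limits leave unreadable from compound 2 to compound 3 cannot be sized, since the limit of > 20000 nM in this assay, at which 3 of the 3 values shown sit, caps every value. Compound 4 `COc1ccc(-c2cc(NO)c(C(=O)Nc3ccc(C)cc3)c(=O)o2)cc1` differs from compound 3 by methoxy in place of methyl on an aromatic carbon. With all three measured steps unreadable, no direction can be read from them. The expectation is that compound 4 will again show a limit, with an estimated value of 30000 nM, between 15000 nM and 100000 nM. The expected step is a step that the limit leaves unreadable from compound 3 to compound 4.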

Compound 4, half-maximal cytotoxic concentration: > 20000 nM
Compound 4 gave a limit, no number (the forecaster's own chance of this, stated with the estimate: 85%); the middle value does not contradict the limit.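

The steps from compound 1, compound 2 and compound 3 to compound 4 cannot be read, because all four compounds share one limit rather than a number: the limit of > 20000 nM in this assay, at which 4 of the 4 values shown sit. The compounds shown leave open what actual value each has in this assay, and so whether swapping these groups changes it at all.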